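A Five-Membered Hetero Ring in Place of Phenyl

This account rests on a few compounds, and the source may have more. Where it says the series, first, only, none or still open, it means among the compounds named here.

Of the compounds shown here, three built on one shared core have been measured in a functional assay on NCI-H460 cells (Homo sapiens) for antiproliferative activity, read by sulforhodamine B assay, with a stated time of 72 h; a lower number here means a stronger inhibitor, a higher number a weaker inhibitor. Compound 1 `CN(CCNCc1cn(-c2ccccc2)nn1)CCNc1ccnc2cc(Cl)ccc12` gives 25000 nM. Compound 2 `CN(CCNCc1cn(-c2ccc(Cl)cc2)nn1)CCNc1ccnc2cc(Cl)ccc12` gives 14000 nM, and compound 3 `CN(CCNCc1cn(Cc2ccccc2)nn1)CCNc1ccnc2cc(Cl)ccc12` gives 32000 nM. Among these three numbers, compound 1 holds the second highest; compound 3 is nearest to it and compound 2 furthest, and both of those gaps fall within the usual scatter of repeated measurements.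

Compound 4 `CN(CCNCc1cn(CCCn2nn[nH]c2=O)nn1)CCNc1ccnc2cc(Cl)ccc12` has not yet been measured. It differs from compound 1 at a single site: a group of 9 heavy atoms (4 carbon, 4 nitrogen, 1 oxygen; one five-membered aromatic ring with 4 hetero atoms) in place of a group of 6 heavy atoms (6 carbon; one six-membered aromatic ring of carbon only), on an aromatic nitrogen.

The measured steps that touch this same site are a 1.3-fold higher number from compound 1 to compound 3 (0.11 log units; within the scatter) and a 2.3-fold higher number from compound 2 to compound 3 (0.36 log units; beyond the scatter), while a 1.8-fold lower number from compound 1 to compound 2 (0.25 log units; within the scatter) alters a substituent on the phenyl itself. None of these steps brings in a ring of hetero atoms, so they offer only indirect guidance. Because a 1.3-fold higher number from compound 1 to compound 3 (0.11 log units; within the scatter) stayed within the scatter, compound 4 is expected to land close to compound 1, with at most a modest drift toward a higher number: a 1.3-fold higher number from compound 1 to compound 4 (0.11 log units; within the scatter). The estimated value for compound 4 is 32000 nM, with a plausible range from 10000 nM to 90000 nM.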

Compound 4, half-maximal inhibitory concentration: > 200000 nM
Compound 4 gave a limit, no number (the forecaster's own chance of this, stated with the estimate: 15%); at least 6.2-fold (0.79 log units) between middle value and limit.
By their numbers in this assay, from the lowest: compounds 2, 1 and 3 (each within the scatter of the next, the first and the last beyond it). At a limit, above all of these: compound 4.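

In this assay, the result for compound 4 is a limit and not a number: the limit of > 200000 nM in this assay, at which 1 of the 4 values shown sits.

The phenyl of compound 1 and the benzyl of compound 3 lie within the scatter of each other at this position on the aromatic nitrogen, but the group of 9 heavy atoms, with its five-membered aromatic ring with 4 hetero atoms, gives an at least 8.0-fold higher number from compound 1 to compound 4 (0.90 log units; beyond the scatter), and from the benzyl compound it gives an at least 6.2-fold higher number from compound 3 to compound 4 (0.79 log units; beyond the scatter). Against the 4-chlorophenyl group the gap is wider still, with an at least 14-fold higher number from compound 2 to compound 4 (1.15 log units; beyond the scatter), so this position is not indifferent to what it carries, even though the carbon-only rings seen earlier hinted at little change; these steps are minimum sizes, and the real gaps may be larger.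

The new group differs from phenyl in its ring, its chain, its hetero atoms and its hydrogen-bond donor and acceptors all at once, so the compounds shown cannot say which of these differences accounts for the result. A longer chain ending in phenyl, or an amine or a carboxylic acid on the same aromatic nitrogen, would be needed to begin separating them.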